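The compounds below may be only part of what the source reports. "The series", "measured", "known", "first", "only" and "open" are said of these compounds alone.

Three compounds set the scene. Compound 1 `Oc1cccc(-c2cc(-c3ccccc3)cc(-c3ccsc3)n2)c1` carries a 3-hydroxyphenyl group and a thiophen-3-yl group on the shared core; compound 2 `Oc1ccc(-c2cc(-c3ccccc3)cc(-c3ccccc3)n2)cc1` pairs a 4-hydroxyphenyl group with a second phenyl group; compound 3 `Oc1ccc(-c2cc(-c3ccccc3)cc(-c3ccsc3)n2)cc1` pairs a 4-hydroxyphenyl group with a thiophen-3-yl group. In a functional assay on DU-145 cells (Homo sapiens) for cytotoxicity, read by ELISA, with a stated time of 2 days (a lower number here means a stronger inhibitor, a higher number a weaker inhibitor), compound 1 gives 11700 nM, compound 2 gives 3000 nM, and compound 3 gives 8500 nM. Compound 3 therefore stands second highest of the three numbers, close to compound 1 and clearly apart from compound 2.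

Two single-point steps have been measured. The move a 1.4-fold lower number from compound 1 to compound 3 (0.14 log units; within the scatter) hardly registers. The move a 2.8-fold higher number from compound 2 to compound 3 (0.45 log units; beyond the scatter) is the one that matters here. It swaps the same group that compound 4 `Oc1ccc(-c2cc(-c3ccccc3)cc(-c3ccc(O)cc3)n2)cc1` now changes: 4-hydroxyphenyl in place of thiophen-3-yl on an aromatic carbon. The group that leaves in going to compound 4 is the one whose arrival raised the number in the step from compound 2 to compound 3, and the step from compound 1 to compound 3 shows that the hydroxyl on a phenyl ring shifts little in this assay. On that basis compound 4 is expected to give a lower number than compound 3, with an estimated step of a 2.4-fold lower number from compound 3 to compound 4 (0.39 log units; beyond the scatter). The expected value for compound 4 is 3500 nM, with a range from 1500 nM to 9000 nM.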

Compound 4, half-maximal inhibitory concentration: 22000 nM
Estimate against measurement, compound 4: 6.3-fold (0.80 log units) below, outside the stated range (above it).
By their numbers in this assay, from the lowest: compound 2; then compounds 3, 1 and 4 (each within the scatter of the next, the first and the last beyond it).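

At this position, next to the ring nitrogen, replacing thiophen-3-yl with 4-hydroxyphenyl in this assay gives a 2.6-fold higher number from compound 3 to compound 4 (0.41 log units; beyond the scatter) and so does not return the number towards that of the phenyl compound; the three groups now seen here have thiophen-3-yl in the middle, with phenyl at the low end and 4-hydroxyphenyl at the high end. The earlier compounds shown here showed hydroxy only as it changed place on the other aryl group, a shift within the scatter, whereas adding hydroxy to the phenyl group at this position gives a 7.3-fold higher number from compound 2 to compound 4 (0.87 log units; beyond the scatter) and is the largest single-place change seen so far. Nothing available explains why this added hydroxy raises the number.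

The compounds shown leave open whether the rise depends on hydroxy itself or would also follow from a methoxy group or an amine on the same phenyl ring. They also leave open whether hydroxy at this position would have the same effect with the 3-hydroxyphenyl group of compound 1 elsewhere on the shared core.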